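This account rests on a few compounds, and the source may have more. Where it says the series, first, only, none or still open, it means among the compounds named here.

Compound 1 `CCCCc1ccc(NS(=O)(=O)c2ccc(N3CCNC3=O)cc2)cc1` gives 770 nM 
Compound 2 `O=C1NCCN1c1ccc(S(=O)(=O)Nc2ccc(OC(F)F)cc2)cc1` gives 760 nM 
Compound 3 `CCCCOc1ccc(NS(=O)(=O)c2ccc(N3CCNC3=O)cc2)cc1` gives 870 nM 

All three values come from a functional assay on MCF7 cells (Homo sapiens) for antiproliferative activity, read by sulforhodamine B assay, with a stated time of 48 h (on this read-out higher numbers stand for weaker inhibition and lower numbers for stronger inhibition), and the compounds differ in one group on the shared core. Compound 3 stands level with the other two, with a 1.1-fold higher number from compound 1 to compound 3 (0.05 log units; within the scatter) and a 1.1-fold higher number from compound 2 to compound 3 (0.06 log units; within the scatter) as its measured steps. Neither step goes beyond the scatter.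

Compound 4 `CCCCCc1ccc(NS(=O)(=O)c2ccc(N3CCNC3=O)cc2)cc1` has no value yet. The change from compound 3 is pentyl in place of butoxy on an aromatic carbon and amounts to pentyl in place of butoxy on an aromatic carbon, para to a large group.

The closest measured change is butoxy in place of butyl, which gave a 1.1-fold higher number from compound 1 to compound 3 (0.05 log units; within the scatter) in this series. The exchange of butyl for difluoromethoxy gave a 1.0-fold lower number from compound 1 to compound 2 (0.01 log units; within the scatter) and also stays small. Compound 1 is the measured compound with an unbroken alkyl chain, and compound 1 gives 770 nM in this assay as the nearest reference. For the measured compounds named here, no measured compound carries pentyl, so a chain longer than butyl remains untested.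

On these steps, no change beyond the scatter is expected in this assay for this exchange. The expected step is a 1.1-fold lower number from compound 3 to compound 4 (0.04 log units; within the scatter) as estimated here. Compound 4 is estimated at 800 nM with an expected range from 400 nM to 1600 nM as a working figure.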

Compound 4, half-maximal inhibitory concentration: > 1000 nM
Compound 4 gave a limit, no number (the forecaster's own chance of this, stated with the estimate: 2%); at least 1.2-fold (0.09 log units) between middle value and limit.
By their numbers in this assay, from the lowest: compounds 2, 1 and 3 (each within the scatter of the next). At a limit, above all of these: compound 4.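

Compound 4 gives a limit of the assay and no number in this assay: the limit of > 1000 nM in this assay, at which 1 of the 4 values shown sits.

Against the three measured compounds, only floors can be read: an at least 1.1-fold higher number from compound 3 to compound 4 (0.06 log units; that floor lies within the scatter), an at least 1.3-fold higher number from compound 2 to compound 4 (0.11 log units; that floor lies within the scatter) and an at least 1.2-fold higher number from compound 1 to compound 4 (0.11 log units; that floor lies within the scatter). Each floor lies within the scatter, so the true size of these steps stays unfixed, and compound 4 can be called neither level with compounds 1, 2 and 3 nor clearly weaker than they are. For the compounds shown here, what is new at this aromatic carbon, para to a large group, is that butyl, butoxy and difluoromethoxy all gave numbers within the scatter of one another, while pentyl is the first group there to give only a limit, so the flat picture from the earlier compounds no longer holds for certain once the chain is pentyl.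

Going by these compounds, whether pentyl marks a real loss against butyl stays open until compound 4 has a number in this assay. Also open, on these data alone, is how a propyl chain, a hexyl chain, an amine or a carboxylic acid at this same carbon would read in this assay.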